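A few compounds are considered here, and "the series" means these few. Any claim that something is new, unique, unknown or untested is made for them only; others in the source may bear on it.

In a functional assay on the whole organism for inhibition, with Rattus norvegicus as the target (on this read-out lower numbers stand for an effect already at smaller amounts and higher numbers for an effect only at larger amounts of compound), compound 3 `Cc1cccc(N/N=C2\CCC(C)n3c2ncc(C(=O)O)c3=O)c1` gives 72.5 umol/kg. Among the numbers obtained so far it stands lowest: compound 1 `CC1CC/C(=N\Nc2cccc(I)c2)c2ncc(C(=O)O)c(=O)n21` gives 1000 umol/kg, and the step of a 14-fold lower number from compound 1 to compound 3 (1.14 log units; beyond the scatter) lies beyond the scatter. Compound 2 `CC1CC/C(=N\Nc2ccc(I)cc2)c2ncc(C(=O)O)c(=O)n21` gives only a limit of the assay, > 1000 umol/kg. The step of an at least 13-fold lower number from compound 2 to compound 3 (1.13 log units; beyond the scatter) is therefore known only as a bound, and the step of a number no lower from compound 1 to compound 2 (the limit leaves the size open) cannot be sized.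

Compound 4 `CCOC(=O)c1cccc(N/N=C2\CCC(C)n3c2ncc(C(=O)O)c3=O)c1` has not yet been tested in this assay. It differs from compound 3 in one place: ethoxycarbonyl in place of methyl on an aromatic carbon. Among the measured compounds shown here, none of the measured steps exchanges methyl for ethoxycarbonyl, so no step matches directly. What the measured steps do show is that exchanging the group on this carbon moves the number strongly, as in a 14-fold lower number from compound 1 to compound 3 (1.14 log units; beyond the scatter), where iodo gave the higher number and methyl the lower. Ethoxycarbonyl is neither, so the direction for compound 4 is open, and a move beyond the scatter in either direction would fit what has been seen.

The estimate for compound 4 is 250 umol/kg, with a range from 60 umol/kg to 1000 umol/kg. For the measured compounds named here, this means an expected step of a 3.4-fold higher number from compound 3 to compound 4 (0.54 log units; beyond the scatter), leaning toward a higher number because the one sized exchange on this ring, a 14-fold lower number from compound 1 to compound 3 (1.14 log units; beyond the scatter), marks methyl as the group with the lowest number so far.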

Compound 4, dose for 50% inhibition: > 100 umol/kg
Compound 4 gave a limit, no number; the forecaster's own chance of this, stated with the estimate: 25%; the middle value lies beyond the limit too.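

Among the compounds shown here, compound 4 is the first compound here to carry a group with oxygen atoms and hydrogen-bond acceptors on this aromatic carbon, and its value, > 100 umol/kg, is a limit of the assay and not a number. Measured against the methyl of compound 3, the exchange for ethoxycarbonyl gives an at least 1.3-fold higher number from compound 3 to compound 4 (0.13 log units; that floor lies within the scatter), so only a floor is known, and that floor lies within the scatter: the result leaves no room for a lower number on compound 4, but it does not set compound 4 clearly apart from compound 3, and the true step could be much larger. The step between compound 1 and compound 4 cannot be read, so whether ethoxycarbonyl behaves more like iodo or more like methyl on this carbon stays undecided.

As far as these compounds go, only methyl, iodo and ethoxycarbonyl appear on this carbon, and methyl has the lowest number among the values that can be read, so it is open whether any other group would go lower. An amine, a carboxylic acid or a longer alkyl chain at this place could still move the number in either direction.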